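This account rests on a few compounds, and the source may have more. Where it says the series, first, only, none or still open, it means among the compounds named here.

Working notes on the series. Of the compounds shown here, two have numbers so far in a physicochemical assay for lipophilicity; on this read-out lower numbers stand for lower lipophilicity and higher numbers for higher lipophilicity. Compound 1 `Cc1cc(Cn2nnnc2Cc2ccccc2)n[nH]1` gives 1.62, the lowest of the two numbers. Compound 2 `CCn1nc(Cn2nnc(Cc3ccccc3)n2)cc1C` gives 2.88, which lies above compound 1 by more than the scatter. Compound 1 therefore marks the low end of what has been measured.

The next compound to be read is compound 3 `CCn1nc(Cn2nnnc2Cc2ccccc2)cc1C`. It keeps the rest of compound 1 and carries ethyl in place of hydrogen on an aromatic nitrogen . That nitrogen belongs to a five-membered aromatic ring with 2 nitrogen, next to the ring atom that bears a methyl group.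

For the measured compounds named here, no measured pair isolates this change, so the size of the step rests on judgement rather than on a measured precedent. A rise beyond the scatter is expected in this assay (estimated a number 0.78 log units higher from compound 1 to compound 3 (beyond the scatter)) . Going by the values given here, the only higher number available is that of compound 2 at 2.88, and the expected range is kept under it. The estimated value for compound 3 is 2.4 (expected range 2 to 2.8).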

Compound 3, partition coefficient: 2.1
Compound 3: the middle estimate sits 0.30 log units above what was measured; the measured number falls inside the stated range.
By their numbers in this assay, from the lowest: compound 1; then compound 3; then compound 2.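

In this assay, ethyl in place of hydrogen on an aromatic nitrogen now has a measured size: a number 0.48 log units higher from compound 1 to compound 3 (beyond the scatter), a modest step. For the compounds shown here, the earlier compounds held no pair differing in this one place, so this is the first direct reading for this nitrogen of the five-membered aromatic ring with 2 nitrogen, next to the ring atom that bears a methyl group. Nothing available accounts for the size of the step, which stands as an observation only.

The compounds shown leave open how methyl or a longer chain such as propyl on this nitrogen would compare with ethyl, and where a chain ending in an amine or a carboxylic acid would fall on this read-out. One pair also cannot tell whether the step would keep its size on a different core, so for now it applies only to the core of compound 1.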